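A Methyl on the Nitrogen of Compound 3

The source may report more compounds than this note shows. Statements on the series, on what has been measured and on what is new or still open speak of the compounds shown alone.

In an ADME assay on MRC5 cells (Homo sapiens) for cytotoxicity, read by fluorescence, with a stated time of 72 h (a higher number here means a weaker inhibitor, a lower number a stronger inhibitor), three compounds with a shared core have been read so far. Compound 1 (`CC1(COc2ccc(OC(F)(F)F)cc2)Cn2cc([N+](=O)[O-])nc2O1`) gives > 64000 nM as a limit of the assay and not a number. Compound 2 (`C[C@]1(COc2ccc(OC(F)(F)F)cc2)Cn2cc([N+](=O)[O-])nc2O1`) gives > 64000 nM as a limit too. Compound 3 (`CC1(CNc2ccc(OC(F)(F)F)cc2)Cn2cc([N+](=O)[O-])nc2O1`) gives > 64000 nM as a limit as well, so it has no number of its own. The whole set therefore stands at the limit of > 64000 nM in this assay, at which 3 of the 3 values shown sit, and shows no ranking.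

Compound 4 (`CN(CC1(C)Cn2cc([N+](=O)[O-])nc2O1)c1ccc(OC(F)(F)F)cc1`) differs from compound 3 by methyl in place of hydrogen on a nitrogen on an aromatic ring and so has methyl in place of hydrogen on a nitrogen on an aromatic ring. Going by the values given here, the only measured step is a step that the two limits leave unreadable from compound 1 to compound 2 and it concerns the fact that one of compounds 1 and 2 is drawn with a defined configuration and the other without, at the place where they differ at another place in the structure. Among the compounds with values here, it offers no size to carry over, and no measured step touches that nitrogen. The expectation therefore rests on compound 3 with its limit of > 64000 nM and on nothing firmer. Expected is a number no higher from compound 3 to compound 4 (the limit leaves the size open) and nothing beyond the scatter, in either direction. Compound 4 is estimated at 64000 nM with an expected range from 30000 nM to 100000 nM and will quite likely be reported only as a limit.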

Compound 4, half-maximal inhibitory concentration: > 64000 nM
Compound 4 gave a limit, no number (the forecaster's own chance of this, stated with the estimate: 85%); the middle value lies on the limit itself.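

In this assay compound 4 gives > 64000 nM, a limit of the assay and not a number. Compound 3 also sits at a limit, so no step can be read between compound 3 and compound 4. The compounds shown leave open how large the half-maximal inhibitory concentration of any of them is, and so what methyl in place of hydrogen on a nitrogen on an aromatic ring does to it.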